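Extending the diol chain of compound 2 by one hydroxymethyl

The source may hold more compounds than are shown below. What is called first, only, known or untested is meant among the compounds shown, and "the series" means these compounds.

The series shares a core carrying a tetrazole-biphenyl benzyl group and an amide-linked side chain, and is compared in a functional assay (Pituitary gland cell) with Rattus norvegicus as the target; on this read-out lower numbers stand for an effect already at smaller amounts and higher numbers for an effect only at larger amounts of compound. Compound 1 `CC(C)[C@H](O)CNC(C)(C)CC(=O)N[C@@H]1CCc2ccccc2N(Cc2ccc(-c3ccccc3-c3nn[nH]n3)cc2)C1=O` gives 1000 nM in this assay. Going by the values given here, compound 2 `CC(C)(CC(=O)N[C@@H]1CCc2ccccc2N(Cc2ccc(-c3ccccc3-c3nn[nH]n3)cc2)C1=O)NC[C@H](O)CO` gives 10 nM in this assay, the lowest of the two numbers; the single step recorded, a 100-fold lower number from compound 1 to compound 2 (2.00 log units; beyond the scatter), shows how much the change at the chain end matters here. Compound 3 `CC(C)(CC(=O)N[C@@H]1CCc2ccccc2N(Cc2ccc(-c3ccccc3-c3nn[nH]n3)cc2)C1=O)NC[C@H](O)[C@@H](O)CO` differs from compound 2 by hydroxymethyl in place of hydrogen on a saturated chain carbon bound to an oxygen on a saturated carbon and a saturated chain carbon, which reads, one bond further out, as 1,2-dihydroxyethyl becoming 1,2,3-trihydroxypropyl. Among the compounds with values here, only the step from compound 1 to compound 2 bears on this region, and it was large; but it swapped one group for another, whereas here a hydroxymethyl is added to a chain already carrying two hydroxyls. Within the data shown here, no step in the data measures such an addition, so he expects compound 3 to stay close to compound 2, with a step of about no change at the digits printed from compound 2 to compound 3 (within the scatter), within the scatter. His estimate for compound 3 in this assay is 10 nM, between 3 nM and 35 nM.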

Compound 3, concentration for half-maximal effect: 40 nM
Compound 3: middle estimate off by 4.0-fold (0.60 log units), on the low side; measured number above the stated range.
By their numbers in this assay, from the lowest: compound 2; then compound 3; then compound 1.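

In this assay, the addition itself registers at this saturated chain carbon: taking 1,2-dihydroxyethyl to 1,2,3-trihydroxypropyl gives a 4.0-fold higher number from compound 2 to compound 3 (0.60 log units; beyond the scatter) and so adds a second effect at this chain end, one that is smaller than the swap of 1-hydroxy-2-methylpropyl for 1,2-dihydroxyethyl and opposite to it in direction. Most of the advantage over the end group of compound 1 nevertheless remains, with 1,2,3-trihydroxypropyl in place of 1-hydroxy-2-methylpropyl giving a 25-fold lower number from compound 1 to compound 3 (1.40 log units; beyond the scatter) and leaving 1,2-dihydroxyethyl with the lowest number of the three. No measurement here offers an explanation for the rise from the shorter diol to the triol.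

The compounds shown leave open whether the rise belongs to the added hydroxyl or to the added chain carbon, a question that a methyl or a methoxymethyl group on the same saturated chain carbon could help to separate. They also leave open how an aminomethyl group or a carboxylic acid at that carbon would read in this assay against the hydroxymethyl of compound 3.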